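Chloro step from compound 1 to compound 3

The source may report more compounds than this note shows. Statements on the series, on what has been measured and on what is new or still open speak of the compounds shown alone.

Of the compounds shown here, two have been read so far in a functional assay on MCF7 cells (Homo sapiens) for cytotoxicity, read by MTT assay, with a stated time of 24 h; on this read-out lower numbers stand for stronger inhibition and higher numbers for weaker inhibition. Compound 1 `CC1(C)OC2O[C@@H](Cc3cn4ccccc4nc3=O)C(OCc3ccccc3)C2O1` gives > 1000000 nM, and this value is a limit, not a number. Compound 2 `O=c1nc2ccccn2cc1Cc1cccc(Oc2ccccc2)c1` gives 243000 nM, which is a measured number. Among the measured compounds shown here, these two compounds differ in more than one place, so no clean step links them.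

Next in line is compound 3 `CC1(C)OC2O[C@@H](Cc3cn4cc(Cl)ccc4nc3=O)C(OCc3ccccc3)C2O1`, which keeps the core of compound 1 and carries chloro in place of hydrogen on an aromatic carbon, two atoms from the ring nitrogen: chloro in place of hydrogen on an aromatic carbon. With compound 1 standing at the limit of > 1000000 nM in this assay, at which 1 of the 2 values shown sits, only a move toward stronger inhibition could appear as a number, and a single chloro is expected to bring a modest move at best in this assay. The expected change is an at least 1.6-fold lower number from compound 1 to compound 3 (0.22 log units; that floor lies within the scatter), and another reading at the limit remains quite possible. For compound 3 the estimated value is 600000 nM, with an expected range from 200000 nM to 1500000 nM.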

Compound 3, half-maximal inhibitory concentration: > 1000000 nM
Compound 3: no number, only a limit; the forecaster's own chance of this, stated with the estimate: 55%; at least 1.6-fold (0.22 log units) between middle value and limit.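

In this assay, compound 1 and compound 3 both read as limits, not numbers, so the chloro step between them cannot be read: the limit of > 1000000 nM in this assay, at which 2 of the 3 values shown sit.

The compounds shown leave open whether chloro in place of hydrogen at this place on the shared core changes the read-out at all.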